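Cyclopropyl on the amide of compound 2

This account rests on a few compounds, and the source may have more. Where it says the series, first, only, none or still open, it means among the compounds named here.

Measured so far in an in vitro assay on BaF3 cells for displacement of a labelled ligand from C-X-C chemokine receptor type 3 (Homo sapiens); a higher number here means a weaker inhibitor, a lower number a stronger inhibitor:
- compound 1, `CC[C@H]1CN(c2ncc(C(=O)NC3CC3)nc2C)CCN1C1CCN(C(=O)c2ccc(Cl)cc2)CC1`: 1.1 nM
- compound 2, `CC[C@H]1CN(c2ncc(C(N)=O)nc2C)[C@H](C)CN1C1CCN(C(=O)c2ccc(Cl)cc2)CC1`: 5.4 nM
- compound 3, `CC[C@H]1CN(c2ncc(C(N)=O)nc2C)[C@@H](C)CN1C1CCN(C(=O)c2ccc(Cl)cc2)CC1`: > 1000 nM

The value of compound 3 in this assay is a limit of the assay, not a number. Among the two numbers, compound 2 stands highest, with compound 1 the nearest and lower. Going by the values given here, the only single-point step measured runs from compound 2 to compound 3: an at least 180-fold higher number from compound 2 to compound 3 (2.26 log units; beyond the scatter), a step that rests on the fact that compounds 2 and 3 differ only in the configuration as drawn and says nothing about the amide.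

Compound 4, `CC[C@H]1CN(c2ncc(C(=O)NC3CC3)nc2C)[C@H](C)CN1C1CCN(C(=O)c2ccc(Cl)cc2)CC1`, carries cyclopropyl in place of hydrogen on an amide-type nitrogen. Among the compounds with values here, no measured step isolates this change. Compound 1 and compound 2 differ both at the amide and at the ring methyl, so their two values only show that a cyclopropylcarbamoyl sits in a strong inhibitor. For compound 4 a modest lowering is therefore expected, a 2.2-fold lower number from compound 2 to compound 4 (0.33 log units; beyond the scatter), close to the scatter. Compound 4 is estimated at 2.5 nM, between 0.8 nM and 8 nM.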

Compound 4, half-maximal inhibitory concentration: 1.3 nM
For compound 4 the middle estimate is 1.9-fold (0.28 log units) above the measured one; measured number inside the range.
By their numbers in this assay, from the lowest: compounds 1 and 4 (each within the scatter of the next); then compound 2. At a limit, above all of these: compound 3.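

In this assay cyclopropyl in place of hydrogen on the amide-type nitrogen can now be read alone, with the ring methyl held the same: it gives a 4.2-fold lower number from compound 2 to compound 4 (0.62 log units; beyond the scatter) and is a modest step beyond the scatter. Going by these compounds alone, the methyl in place of hydrogen on a saturated ring carbon can also be read alone for the first time, and with the cyclopropylcarbamoyl present it gives a 1.2-fold higher number from compound 1 to compound 4 (0.07 log units; within the scatter) and so cannot be told from hydrogen here. Nothing measured for these compounds gives a cause for either step.

Open, as far as these compounds go, is whether cyclobutyl or a hydroxyethyl chain on that nitrogen would read the same as cyclopropyl. Also open, from the compounds shown here alone, is whether cyclopropyl on the amide would bring the configuration of compound 3 back into a measurable range, since its > 1000 nM is a limit of the assay.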